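Swapping fluoro for chloro on the sulfonyl phenyl ring

The source may hold more compounds than are shown below. What is called first, only, known or untested is meant among the compounds shown, and "the series" means these compounds.

Three related compounds have been tested in an ADME assay on cells (Hepatocyte, Mus musculus) for cytotoxicity, read by MTT assay, with a stated time of 24 h; on this read-out lower numbers stand for higher toxicity in this test and higher numbers for lower toxicity in this test. Compound 1 `Cc1ccc(-c2nn(-c3ccccc3)cc2-c2nc3ccccc3n2S(=O)(=O)c2ccc(F)cc2)cc1` gives 167000 nM in this assay. Compound 2 `Cc1ccc(-c2nn(-c3ccccc3)cc2-c2nc3ccccc3n2S(=O)(=O)c2ccc(Cl)cc2)cc1` differs from compound 1 by chloro in place of fluoro on an aromatic carbon. In this assay compound 2 gives 216000 nM, which amounts to a 1.3-fold higher number from compound 1 to compound 2 (0.11 log units; within the scatter). Compound 3 `O=S(=O)(c1ccc(F)cc1)n1c(-c2cn(-c3ccccc3)nc2-c2ccc(C(F)(F)F)cc2)nc2ccccc21` carries a different core: it differs from compound 1 by trifluoromethyl in place of methyl on an aromatic carbon. In this assay compound 3 gives 83300 nM, which reads as a 2.0-fold lower number from compound 1 to compound 3 (0.30 log units; within the scatter). For the measured compounds named here, for compound 2 and compound 3 no single step was computed; their two numbers simply stand as given.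

Compound 4 `O=S(=O)(c1ccc(Cl)cc1)n1c(-c2cn(-c3ccccc3)nc2-c2ccc(C(F)(F)F)cc2)nc2ccccc21` has not yet been measured. It differs from compound 3 by chloro in place of fluoro on an aromatic carbon. Going by the values given here, this is the same change that turns compound 1 into compound 2, made at the same place on the ring, so the earlier pair is the only guide to what it may do here. Since that measured step is a 1.3-fold higher number from compound 1 to compound 2 (0.11 log units; within the scatter) and lies within the scatter, the number for compound 4 is expected to sit close to that of compound 3. Among the compounds with values here, the step expected from compound 3 to compound 4 is a 1.3-fold higher number from compound 3 to compound 4 (0.11 log units; within the scatter), a size chosen because a 1.3-fold higher number from compound 1 to compound 2 (0.11 log units; within the scatter) is the sole measured example of this change. The expectation rests on one pair only, and compound 3 carries a trifluoromethyl group where compound 1 carries a methyl, so the outcome could differ. For compound 4 the estimated value in this assay is 108000 nM, with a likely range from 55000 nM to 210000 nM.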

Compound 4, half-maximal cytotoxic concentration: 173000 nM
Estimate against measurement, compound 4: 1.6-fold (0.20 log units) below; low and high end bracket the measured number.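

In this assay, chloro in place of fluoro on the sulfonyl phenyl ring gives a 2.1-fold higher number from compound 3 to compound 4 (0.32 log units; beyond the scatter), and set beside the same change on the core of compound 1, the two steps do not differ beyond what repeat measurements would allow: the same change on two cores in this assay, a 1.3-fold higher number (0.11 log units; within the scatter) from compound 1 to compound 2 and a 2.1-fold higher number (0.32 log units; beyond the scatter) from compound 3 to compound 4, 1.6-fold (0.21 log units) apart, within the scatter of two such steps

The trifluoromethyl for methyl change, read with chloro on the ring, gives a 1.2-fold lower number from compound 2 to compound 4 (0.10 log units; within the scatter), and it also agrees with its earlier counterpart: the same change on two cores in this assay, a 2.0-fold lower number (0.30 log units; within the scatter) from compound 1 to compound 3 and a 1.2-fold lower number (0.10 log units; within the scatter) from compound 2 to compound 4, 1.6-fold (0.21 log units) apart, within the scatter of two such steps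

So within these four compounds, each change can be carried from one core to the other without a detectable difference, although this rests on just two examples of each change and does not prove that the steps are identical or that they would hold on any other core.

The compounds shown leave open whether a bromo or a methoxy group in place of the chloro would behave in the same way on the sulfonyl phenyl ring. They also leave open what a carboxylic acid or an amine in place of the trifluoromethyl would do to the number in this assay.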